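The source may hold more compounds than are shown below. What is called first, only, known or untested is meant among the compounds shown, and "the series" means these compounds.

Measured so far in a functional assay on MDA-MB-231 cells (Homo sapiens) for cytotoxicity, read by MTT assay, with a stated time of 48 h; on this read-out lower numbers stand for stronger inhibition and higher numbers for weaker inhibition:

Compound 1, `CC(C)=CCC/C(C)=C/CC/C(C)=C/CSc1ccccc1C(=O)N[C@@H](C)C(=O)OC(C)CCOc1no[n+]([O-])c1S(=O)(=O)c1ccccc1`, gives 5050 nM in this assay.
Compound 2, `CC(C)=CCC/C(C)=C/CC/C(C)=C/CSc1ccccc1C(=O)N[C@@H](C)C(=O)OCCOCCOc1no[n+]([O-])c1S(=O)(=O)c1ccccc1`, gives 4210 nM in this assay.
Compound 3, `CC(C)=CCC/C(C)=C/CC/C(C)=C/CSc1ccccc1C(=O)NCC(=O)OC(C)CCOc1no[n+]([O-])c1S(=O)(=O)c1ccccc1`, gives 7260 nM in this assay.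

The three values lie close together, and none of the gaps between them is large enough to count as a real difference in this assay. Compound 1 and compound 3 differ in a single place: hydrogen in place of methyl on a saturated chain carbon bound to an amide-type nitrogen and a carbonyl carbon. That change produced a 1.4-fold higher number from compound 1 to compound 3 (0.16 log units; within the scatter), a shift too small to separate from the normal run-to-run variation. Compound 2 and compound 1 differ in more than one place; the difference between their cores is not broken down here.

Compound 4, `CC(C)=CCC/C(C)=C/CC/C(C)=C/CSc1ccccc1C(=O)NCC(=O)OCCOCCOc1no[n+]([O-])c1S(=O)(=O)c1ccccc1`, has not yet been measured. It relates to compound 2 exactly as compound 3 relates to compound 1: hydrogen in place of methyl on a saturated chain carbon bound to an amide-type nitrogen and a carbonyl carbon. The place is described in the same words in both cases, so this is the same change, made on a second core.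

The expectation for compound 4 therefore rests on one observation, namely a 1.4-fold higher number from compound 1 to compound 3 (0.16 log units; within the scatter), applied to the value of compound 2 in this assay. Within the data shown here, compound 4 is expected to show a similarly small step, a 1.4-fold higher number from compound 2 to compound 4 (0.15 log units; within the scatter), because the only precedent is a 1.4-fold higher number from compound 1 to compound 3 (0.16 log units; within the scatter). On that basis compound 4 is estimated at 5900 nM, plausibly anywhere from 3000 nM to 11000 nM.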

Compound 4, half-maximal inhibitory concentration: 2410 nM
Compound 4: the middle estimate sits 2.4-fold (0.39 log units) above what was measured; measured number below the stated range.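

In this assay the second core gives a 1.7-fold lower number from compound 2 to compound 4 (0.24 log units; within the scatter) when hydrogen takes the place of methyl on the saturated chain carbon bound to an amide-type nitrogen and a carbonyl carbon. Set beside the first case, this step cannot be told apart from it, and neither step stands clear of the ordinary variation between repeated measurements: the same change on two cores in this assay, a 1.4-fold higher number (0.16 log units; within the scatter) from compound 1 to compound 3 and a 1.7-fold lower number (0.24 log units; within the scatter) from compound 2 to compound 4, 2.5-fold (0.40 log units) apart, within the scatter of two such steps

On these two cores, then, the swap of methyl for hydrogen has no effect in this cell test that can be separated from noise, which is consistent with the small step carrying over from one core to the other. This does not show that the change truly does nothing, nor that the two cores respond alike, since a real small effect of either sign could hide inside the scatter of just two pairs.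

The compounds shown leave open what a larger group at this carbon would do, such as an isopropyl or benzyl group, or a longer chain ending in an amine or a carboxylic acid. They also leave open whether the step stays this small on cores carrying a different linker or in other cell lines.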